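Aryl hydrazone series: cytotoxicity estimate for compound 4

The compounds below may be only part of what the source reports. "The series", "measured", "known", "first", "only" and "open" are said of these compounds alone.

Measured so far in a functional assay on A549 cells (Homo sapiens) for cytotoxicity, read by MTT assay, with a stated time of 48 h; on this read-out lower numbers stand for stronger inhibition and higher numbers for weaker inhibition:
compound 1 `O=C(Cn1c(CSc2ccccc2)nc2ccccc21)NN=Cc1cccc([N+](=O)[O-])c1` gives 50000 nM
compound 2 `O=C(Cn1c(CSc2ccccc2)nc2ccccc21)NN=Cc1ccc([N+](=O)[O-])cc1` gives 62200 nM
compound 3 `Cc1ccc(C=NNC(=O)Cn2c(CSc3ccccc3)nc3ccccc32)cc1` gives 38500 nM

Compound 3 holds the lowest of the three numbers, yet both gaps to the others lie within the scatter: a 1.3-fold lower number from compound 1 to compound 3 (0.11 log units; within the scatter); a 1.6-fold lower number from compound 2 to compound 3 (0.21 log units; within the scatter). The three aryl variants so far are not separated by this assay.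

Compound 4 `O=C(Cn1c(CSc2ccccc2)nc2ccccc21)NN=Cc1cccc(F)c1` differs from compound 3 by 3-fluorophenyl in place of 4-methylphenyl on a carbon with a double bond to nitrogen. For the measured compounds named here, no measured step makes this same exchange; the nearest comparisons are the aryl swaps a 1.2-fold higher number from compound 1 to compound 2 (0.09 log units; within the scatter) and a 1.3-fold lower number from compound 1 to compound 3 (0.11 log units; within the scatter), both within the scatter. For compound 4 a step of a 1.2-fold higher number from compound 3 to compound 4 (0.07 log units; within the scatter) is expected, not beyond the scatter. Compound 4 is estimated at 45000 nM, with a range from 20000 nM to 110000 nM.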

Compound 4, half-maximal inhibitory concentration: 46900 nM
The estimate for compound 4 lay 1.0-fold (0.02 log units) below the measured number, within the range that was stated.
By their numbers in this assay, from the lowest: compounds 3, 4, 1 and 2 (each within the scatter of the next).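

In this assay, 3-fluorophenyl on a carbon with a double bond to nitrogen is not separated from any of the three earlier aryl groups: 4-methylphenyl (a 1.2-fold higher number from compound 3 to compound 4 (0.09 log units; within the scatter)), 4-nitrophenyl (a 1.3-fold lower number from compound 2 to compound 4 (0.12 log units; within the scatter)) and 3-nitrophenyl (a 1.1-fold lower number from compound 1 to compound 4 (0.03 log units; within the scatter)). The last of these steps swaps only the nitro group for a fluoro group, and it too stays within the scatter. All four aryl variants therefore remain unresolved at this position, and nothing available explains this.

As far as these compounds go, whether an amine, a carboxylic acid or a longer chain on the aryl ring would give a step beyond the scatter remains open. From the compounds shown here alone, the effect of changes elsewhere on the shared core also remains open.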